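This account rests on a few compounds, and the source may have more. Where it says the series, first, only, none or still open, it means among the compounds named here.

Compound 1 `O=S(=O)(Nc1ccc(-c2nc3cc(NS(=O)(=O)c4ccc(Cl)s4)ccc3o2)cc1)c1ccc(Cl)s1` is the weaker of the two measured compounds in a functional assay on DLD-1 cells (Homo sapiens) for cytotoxicity, read by resazurin assay, with a stated time of 48 h; on this read-out lower numbers stand for an effect already at smaller amounts and higher numbers for an effect only at larger amounts of compound: compound 1 gives 33000 nM, whereas compound 2 `COc1ccc(S(=O)(=O)Nc2ccc3oc(-c4ccc(NC(=O)c5ccc(Cl)s5)cc4)nc3c2)cc1` gives 4600 nM, a gap beyond the usual scatter. Compound 3 `O=S(=O)(Nc1ccc(-c2nc3cc(NS(=O)(=O)c4ccc(Cl)s4)ccc3o2)cc1)c1ccc(Cl)c(C(F)(F)F)c1` differs from compound 1 in one place (4-chloro-3-(trifluoromethyl)phenyl in place of 5-chlorothiophen-2-yl on a sulfonyl sulfur). For the measured compounds named here, no measured pair isolates this change, so the expected step from compound 1 to compound 3 in this assay is small, a 1.5-fold lower number from compound 1 to compound 3 (0.18 log units; within the scatter), with no firm direction. On that basis compound 3 is estimated at 22000 nM, expected to fall between 7000 nM and 60000 nM.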

Compound 3, half-maximal effective concentration: 22000 nM
Estimate against measurement, compound 3: no gap at the digits printed; the range from low to high includes it.
By their numbers in this assay, from the lowest: compound 2; then compounds 3 and 1 (each within the scatter of the next).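

In this assay, replacing 5-chlorothiophen-2-yl on this sulfonyl sulfur with 4-chloro-3-(trifluoromethyl)phenyl gives a 1.5-fold lower number from compound 1 to compound 3 (0.18 log units; within the scatter). For the compounds shown here, this is the first direct reading at this place, and it shows that a larger, carbon-only aromatic ring with no hetero atom can enter without a change beyond the scatter. Nothing available explains this outcome. Going by these compounds, it remains open whether a non-aromatic group, such as an amine or a carboxylic acid, would shift the number here, and whether the same exchange on the other sulfonyl sulfur would behave alike.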